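The source may report more compounds than this note shows. Statements on the series, on what has been measured and on what is new or still open speak of the compounds shown alone.

Working notes on the series, all numbers from an ADME assay on BJ cells (Homo sapiens), read by MTT assay, with a stated time of 3 days; on this read-out higher numbers stand for weaker inhibition and lower numbers for stronger inhibition. Compound 1 `CNc1ncnc2[nH]cc(Sc3cccs3)c12` gives 132000 nM, compound 2 `c1csc(Sc2c[nH]c3ncnc(-c4cccs4)c23)c1` gives 23400 nM, and compound 3 `c1coc(-c2ncnc3[nH]cc(Sc4cccs4)c23)c1` gives 22100 nM. Compound 3 therefore sits at the low end of these numbers level with compound 2, as a 1.1-fold lower number from compound 2 to compound 3 (0.02 log units; within the scatter) shows, and clearly under compound 1, as a 6.0-fold lower number from compound 1 to compound 3 (0.78 log units; beyond the scatter) shows.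

The next compound is compound 4 `COc1ncnc2[nH]cc(Sc3cccs3)c12`, which carries methoxy in place of furan-2-yl on an aromatic carbon.

Going by the values given here, two measured steps bear on this change. Both replace methylamino, a group with no ring, with a five-membered aromatic ring: a 5.6-fold lower number from compound 1 to compound 2 (0.75 log units; beyond the scatter) and a 6.0-fold lower number from compound 1 to compound 3 (0.78 log units; beyond the scatter). Both are modest, and they agree. Methoxy also has no ring, so the change to compound 4 resembles the reverse of these steps. Among the compounds with values here, no measured compound other than compound 4 carries methoxy, however, so the resemblance to methylamino is untested and the size remains uncertain.

In this assay, a modest rise is expected, probably no larger than the reverse of those steps, and the expected step is a 2.9-fold higher number from compound 3 to compound 4 (0.47 log units; beyond the scatter). For compound 4 the estimated value is 65000 nM, with an expected range of 22000 nM to 160000 nM.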

Compound 4, half-maximal inhibitory concentration: 123000 nM
Beside the measured number, compound 4's estimate is 1.9-fold (0.28 log units) below it, within the range that was stated.
By their numbers in this assay, from the lowest: compounds 3 and 2 (each within the scatter of the next); then compounds 4 and 1 (each within the scatter of the next).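

In this assay, the result shows that the groups on this aromatic carbon fall into two levels: methoxy and methylamino read alike, with a 1.1-fold lower number from compound 1 to compound 4 (0.03 log units; within the scatter), while replacing either five-membered aromatic ring with methoxy gives a similar rise, with a 5.6-fold higher number from compound 3 to compound 4 (0.75 log units; beyond the scatter) and a 5.3-fold higher number from compound 2 to compound 4 (0.72 log units; beyond the scatter). Furan-2-yl and methoxy have the same hydrogen-bond donor and acceptor counts, so those counts do not separate the two levels across the step from compound 3 to compound 4, whereas ring content and heavy-atom count do differ. No measured evidence on the series explains this split.

From the compounds shown here alone, it remains open whether the split follows the aromatic ring itself or simply the larger group, which a saturated ring such as morpholine or a longer chain such as butoxy on this carbon could help separate. Going by these compounds, it is also open whether the same two levels would hold if the thiophen-2-yl group attached through sulfur on the shared core gave way to another group, such as phenyl.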